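Swapping a phenyltetrazole for benzimidazole on the thioether

The compounds below may be only part of what the source reports. "The series", "measured", "known", "first", "only" and "open" are said of these compounds alone.

Measured compounds:
Compound 1, `CC(C)[C@H](NC(=O)COc1cccc2ccccc12)C(=O)N[C@@H](CC(=O)O)C(=O)CSC1=NCCS1`, gives only a limit in a functional assay on Jurkat cells (Homo sapiens) for inhibition (a higher number here means a weaker inhibitor, a lower number a stronger inhibitor), namely > 200000 nM.
Compound 2, `CC(C)[C@H](NC(=O)COc1cccc2ccccc12)C(=O)N[C@@H](CC(=O)O)C(=O)CSc1nc(-c2ccccc2)no1`, gives 102000 nM in this assay.
Compound 3, `CC(C)[C@H](NC(=O)COc1cccc2ccccc12)C(=O)N[C@@H](CC(=O)O)C(=O)CSc1nnnn1-c1ccccc1`, gives 153000 nM in this assay.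

All three share the same core and differ only in the ring attached to the sulfur. Compound 1 sits at the limit (the limit of > 200000 nM in this assay, at which 1 of the 3 values shown sits), so no number is known for it. Compound 2 and compound 3 lie within the usual scatter of each other, the step reading a 1.5-fold higher number from compound 2 to compound 3 (0.18 log units; within the scatter). The two steps from compound 1, an at least 1.9-fold lower number from compound 1 to compound 2 (0.29 log units; that floor lies within the scatter) and an at least 1.3-fold lower number from compound 1 to compound 3 (0.11 log units; that floor lies within the scatter), are only floors, since compound 1 is a limit.

Compound 4, `CC(C)[C@H](NC(=O)COc1cccc2ccccc12)C(=O)N[C@@H](CC(=O)O)C(=O)CSc1nc2ccccc2[nH]1`, carries the change (1H-benzimidazol-2-yl in place of 1-phenyl-1H-tetrazol-5-yl on a sulfur). Among the compounds with values here, the only step measured between two aromatic rings on this sulfur, from compound 2 to compound 3, stays within the scatter, so no step beyond the scatter is expected here either. Compound 4 is expected to give about 120000 nM, within 40000 nM to 300000 nM. The step this estimate implies is expected to read a 1.3-fold lower number from compound 3 to compound 4 (0.11 log units; within the scatter).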

Compound 4, half-maximal inhibitory concentration: > 200000 nM
Compound 4 gave a limit, no number; the forecaster's own chance of this, stated with the estimate: 30%; middle value at least 1.6-fold (0.22 log units) from the limit.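

Compound 4 gives only a limit, not a number, and it sits at the same limit as compound 1: the limit of > 200000 nM in this assay, at which 2 of the 4 values shown sit.

Both readable steps are floors, an at least 1.3-fold higher number from compound 3 to compound 4 (0.11 log units; that floor lies within the scatter) and an at least 1.9-fold higher number from compound 2 to compound 4 (0.29 log units; that floor lies within the scatter), so neither shows a change beyond the scatter, though the true steps could be larger. Even so, 1H-benzimidazol-2-yl is the only aromatic group shown on this sulfur that yields no number, so this swap brings no gain in inhibition, and the step between compound 1 and compound 4 cannot be read because both are limits.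

From the compounds shown here alone, how far compound 4 really lies from compound 2 and compound 3 stays open. Also open, going by these compounds, is whether the ring hydrogen of the benzimidazole matters, which a 1-methyl-1H-benzimidazol-2-yl group on the same sulfur would test.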